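Lengthening the Amine-Bearing Chain: Compound 4 Expected

A few compounds are considered here, and "the series" means these few. Any claim that something is new, unique, unknown or untested is made for them only; others in the source may bear on it.

Compound 1 `CN(C)CCCCCCOc1ccc2oc(-c3ccccc3)cc(=O)c2c1` gives 335 nM in an assay on isolated protein (Cavia porcellus) with Sigma non-opioid intracellular receptor 1 (Homo sapiens) as the target, read by radioligand binding; on this read-out higher numbers stand for weaker inhibition and lower numbers for stronger inhibition.
Compound 2 `CN(C)CCCCCCCOc1ccc2oc(-c3ccccc3)cc(=O)c2c1` gives 188 nM in this assay.
Compound 3 `CN(C)CCCCCCCCCOc1ccc2oc(-c3ccccc3)cc(=O)c2c1` gives 202 nM in this assay.

Compound 3 stands second highest of these three numbers; its nearest neighbour is compound 2, with a 1.1-fold higher number from compound 2 to compound 3 (0.03 log units; within the scatter), and its furthest is compound 1, with a 1.7-fold lower number from compound 1 to compound 3 (0.22 log units; within the scatter). Compound 4 `CN(C)CCCCCCCCCCOc1ccc2oc(-c3ccccc3)cc(=O)c2c1` differs from compound 3 only by chain length: (dimethylamino)methyl in place of dimethylamino on a saturated chain carbon, nine bonds along the chain from an oxygen on an aromatic ring. The earlier chain extensions bear directly on this step: a 1.8-fold lower number from compound 1 to compound 2 (0.25 log units; within the scatter) and a 1.1-fold higher number from compound 2 to compound 3 (0.03 log units; within the scatter), neither beyond the scatter. The expected step in this assay is therefore a 1.0-fold higher number from compound 3 to compound 4 (0.02 log units; within the scatter), with no change beyond the scatter. Compound 4 is expected to give 210 nM, within a range from 100 nM to 440 nM.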

Compound 4, half-maximal inhibitory concentration: 341 nM
For compound 4 the middle estimate is 1.6-fold (0.21 log units) below the measured one; low and high end bracket the measured number.
By their numbers in this assay, from the lowest: compounds 2, 3, 1 and 4 (each within the scatter of the next).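

In this assay, within the data shown here, lengthening the chain once more gives a 1.7-fold higher number from compound 3 to compound 4 (0.23 log units; within the scatter), and the longer jumps give a 1.8-fold higher number from compound 2 to compound 4 (0.26 log units; within the scatter) and a 1.0-fold higher number from compound 1 to compound 4 (0.01 log units; within the scatter), so no single step across this series of chain lengths stands clear of the scatter. The new result does show that the same extension need not act alike at every chain length: the same change on two cores in this assay, a 1.8-fold lower number (0.25 log units; within the scatter) from compound 1 to compound 2 and a 1.7-fold higher number (0.23 log units; within the scatter) from compound 3 to compound 4, 3.0-fold (0.48 log units) apart, beyond the scatter of two such steps The same holds for a longer extension: the same change on two cores in this assay, a 1.7-fold lower number (0.22 log units; within the scatter) from compound 1 to compound 3 and a 1.8-fold higher number (0.26 log units; within the scatter) from compound 2 to compound 4, 3.0-fold (0.48 log units) apart, beyond the scatter of two such steps The compounds shown leave open how a longer chain than that of compound 4 would read in this assay. They also leave open what a diethylamino group at the chain end would give in place of dimethylamino.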